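Swapping the aryl group on the isoxazole arm

This account rests on a few compounds, and the source may have more. Where it says the series, first, only, none or still open, it means among the compounds named here.

Two members of this series have numbers in a functional assay on COLO 205 cells (Homo sapiens) for antiproliferative activity, read by MTT assay; on this read-out higher numbers stand for weaker inhibition and lower numbers for stronger inhibition. Compound 1 `C#CCN(c1nc2ccc(F)cc2s1)c1nc2ccc(OC)cc2s1` carries a propargyl group on the central nitrogen and gives 30300 nM. Compound 2 `COc1ccc(-c2cc(CN(c3nc4ccc(F)cc4s3)c3nc4ccc(OC)cc4s3)on2)cc1` carries instead a methylene-linked isoxazole bearing a 4-methoxyphenyl group and gives 11400 nM, the lower of the two numbers, with a gap to compound 1 that is beyond the usual scatter.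

Compound 3 `COc1ccc2nc(N(Cc3cc(-c4ccccc4F)no3)c3nc4ccc(F)cc4s3)sc2c1` keeps the core and the isoxazole arm of compound 2 and changes only the aryl group on it: 2-fluorophenyl in place of 4-methoxyphenyl on an aromatic carbon. Among the measured compounds shown here, no pair differing in one place has been measured, so nothing tells how this exchange will read out. The expected step of a 1.1-fold higher number from compound 2 to compound 3 (0.02 log units; within the scatter) is therefore small and not beyond the scatter, in either direction. On that basis compound 3 is estimated at 12000 nM, within a range from 4000 nM to 40000 nM.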

Compound 3, half-maximal inhibitory concentration: 13400 nM
For compound 3 the middle estimate is 1.1-fold (0.05 log units) below the measured one, and the stated range covers the measured number.
By their numbers in this assay, from the lowest: compounds 2 and 3 (each within the scatter of the next); then compound 1.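

In this assay, among the compounds shown here, the exchange of 4-methoxyphenyl for 2-fluorophenyl on the aromatic carbon of the isoxazole gives a 1.2-fold higher number from compound 2 to compound 3 (0.07 log units; within the scatter) and is the first step that can be read in one place. At this position, the read-out does not separate the two aryl groups, even though the leaving group counts one hydrogen-bond acceptor and the entering group none. No measurement bears on why these two aryl groups read out alike.

The exchange alters both the substituent and where it sits on the phenyl ring, so the two contributions cannot be told apart. From the compounds shown here alone, how an unsubstituted phenyl, a pyridine ring or a phenyl carrying a carboxylic acid would read out at this position remains open.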